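A few compounds are considered here, and "the series" means these few. Any claim that something is new, unique, unknown or untested is made for them only; others in the source may bear on it.

Measured compounds so far:
- compound 1, `CCOC(=O)N[C@H](C)c1nc2ccc(F)cc2s1`, 4.2
- compound 2, `CCCOC(=O)N[C@H](C)c1nc2ccc(F)cc2s1`, 4.56
- compound 3, `CC(C)COC(=O)N[C@H](C)c1nc2ccc(F)cc2s1`, 4.24

All three values come from a physicochemical assay for lipophilicity, using the shake flask method, measured as octanol-water partition, with a stated time of 15 min; on this read-out higher numbers stand for higher lipophilicity and lower numbers for lower lipophilicity. Compound 1 stands lowest of the three; compound 3 lies within the scatter of it, and compound 2 sits beyond the scatter above it.

Compound 4, `C[C@@H](NC(=O)OCC(F)(F)C(F)F)c1nc2ccc(F)cc2s1`, is not yet measured in this assay. It differs from compound 1 by 1,1,2,2-tetrafluoroethyl in place of methyl on a saturated chain carbon bound to an oxygen next to a carbonyl group.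

The measured steps that bear on this are those that lengthen the chain on the carbamate side. Lengthening by one carbon gave a number 0.36 log units higher from compound 1 to compound 2 (beyond the scatter), whereas the branched isopropyl gave a number 0.04 log units higher from compound 1 to compound 3 (within the scatter), and moving from the straight to the branched chain gave a number 0.32 log units lower from compound 2 to compound 3 (beyond the scatter). Growth of the chain thus gave at most a modest rise. Compound 4 adds more heavy atoms than either, with 2 carbon and 4 fluorine entering, and no donors or acceptors change. A modest upward step in this assay is therefore expected, a number 0.40 log units higher from compound 1 to compound 4 (beyond the scatter), with wide uncertainty since no fluorinated chain has been measured. For compound 4 the estimate is 4.6, between 4.1 and 5.1.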

Compound 4, partition coefficient: 2.92
The estimate for compound 4 lay 1.68 log units above the measured number; measured number outside the range, below it.
By their numbers in this assay, from the lowest: compound 4; then compounds 1 and 3 (each within the scatter of the next); then compound 2.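

In this assay, 1,1,2,2-tetrafluoroethyl in place of methyl gives a number 1.28 log units lower from compound 1 to compound 4 (beyond the scatter), a large step and the first at this position to take the number down from compound 1. The same group gives a number 1.32 log units lower from compound 3 to compound 4 (beyond the scatter) against isopropyl and a number 1.64 log units lower from compound 2 to compound 4 (beyond the scatter) against ethyl, so chain growth alone does not set the number here: the fluorinated chain moves it much further than the non-fluorinated chains did, and in the opposite direction to the rise from compound 1 to compound 2. Nothing at hand accounts for this fall.

The compounds shown leave open whether the fall follows the number of fluorine atoms or their place on the chain, which a 2-fluoroethyl or 2,2,2-trifluoroethyl chain would test. Also open, as far as these compounds go, is how a longer fluorinated chain, or an amine on the chain, would read in this assay.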